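Working notes: from methyl to methoxycarbonyl in the series

The source may hold more compounds than are shown below. What is called first, only, known or untested is meant among the compounds shown, and "the series" means these compounds.

Three compounds with a shared core have entries in an ADME assay on MCF10 cells (Homo sapiens) for cytotoxicity (a higher number here means a weaker inhibitor, a lower number a stronger inhibitor), so far: compound 1 (`CCc1nc(N)nc(N)c1C#CC(C)c1ccc(-c2ccccc2)cc1OC`), compound 2 (`CCc1nc(N)nc(N)c1C#CC(C)c1ccc(-c2ccc(O)cc2)cc1OC`) and compound 3 (`CCc1nc(N)nc(N)c1C#CC(C)c1ccc(-c2ccc(C)cc2)cc1OC`). Only one of these entries is a number. Compound 1 stands as "not determined" (no result reported) in the record. Compound 2 gives 148000 nM as its read-out. Among the compounds with values here, compound 3 stands as "not determined" (no result reported) in the record, so it has no single number, and no measured step links any two members.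

The next compound is compound 4 (`CCc1nc(N)nc(N)c1C#CC(C)c1ccc(-c2ccc(C(=O)OC)cc2)cc1OC`). The change is methoxycarbonyl in place of methyl on an aromatic carbon and amounts to methoxycarbonyl in place of methyl on an aromatic carbon, para to a large group. Within the data shown here, with no measured step to size this change, and no number for compound 3 to start from, the working expectation in this assay is no step beyond the scatter and no favoured direction. Among the measured compounds shown here, the only anchor is compound 2 at 148000 nM as the single measured value, and the expectation is for a result in that region, with a wide margin given how little the data show. For compound 4 the expected value is 120000 nM with an estimated range from 40000 nM to 300000 nM as the working bounds.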

Compound 4, half-maximal inhibitory concentration: 96000 nM
The estimate for compound 4 lay 1.3-fold (0.10 log units) above the measured number, within the range that was stated.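

The series now holds its first readable step in this assay at this position, on the aromatic carbon para to a large group: methoxycarbonyl in place of hydroxy gives a 1.5-fold lower number from compound 2 to compound 4 (0.19 log units; within the scatter) on the shared core. Hydroxy and methoxycarbonyl therefore cannot be told apart at this position in this read-out, and this single pair is all that supports that statement. Nothing available here bears on why these two groups give values within the scatter of each other.

The steps that run through compound 1 and compound 3 cannot be read, so the exchange of methyl for methoxycarbonyl itself remains unsized, as does any comparison with the unsubstituted phenyl of compound 1. From the compounds shown here alone, whether an amine, a carboxylic acid or a longer chain at this same position would also stay within the scatter of compound 4 in this assay remains open, and a single step gives no basis for extending the result to them.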